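Swapping fluoro for methyl in an open-chain amide

The source may report more compounds than this note shows. Statements on the series, on what has been measured and on what is new or still open speak of the compounds shown alone.

Compound 1 `COc1ccc(C23CCC(=O)N2CCCO3)cc1`: < 150 mg/kg
Compound 2 `O=C(CCC(=O)c1ccc(F)cc1)NCCCO`: 500 mg/kg

Of the compounds shown here, two have been tested in a functional assay on the whole organism (Central nervous system) with Mus musculus as the target; a lower number here means that less compound is needed, a higher number that more compound is needed for the effect. For compound 1 the value < 150 mg/kg is a limit of the assay and not a number (the limit of < 150 mg/kg in this assay, at which 1 of the 2 values shown sits). Within the data shown here, compound 2 gives 500 mg/kg and is thus the only compound with a definite number here. Compound 3 `Cc1ccc(C(=O)CCC(=O)NCCCO)cc1` differs from compound 2 in one place: methyl in place of fluoro on an aromatic carbon. Among the measured compounds shown here, no pair of measured compounds differs in a single place, so the size of such an exchange cannot be read from these data. An exchange of one heavy atom for another is expected to shift the dose only a little, with no clear direction, and to stay within the usual scatter. Compound 3 is therefore estimated at 400 mg/kg, between 200 mg/kg and 800 mg/kg. The step from compound 2 to compound 3 is expected to be a 1.3-fold lower number from compound 2 to compound 3 (0.10 log units; within the scatter).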

Compound 3, dose for half-maximal effect: 700 mg/kg
For compound 3 the middle estimate is 1.8-fold (0.24 log units) below the measured one; the measured number falls inside the stated range.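

Among these compounds, this pair gives the first direct reading of a single exchange in the open-chain amide: on the aromatic carbon para to a large group, methyl in place of fluoro gives a 1.4-fold higher number from compound 2 to compound 3 (0.15 log units; within the scatter). In this assay that step stays within the scatter, so the two compounds cannot be told apart, and this position accepts one heavy atom in place of another with no readable change. No measurement shown bears on the reason for this result.

Going by these compounds, whether a group such as an amine or a carboxylic acid on the same aromatic carbon would give a readable step remains open. Compound 1 gives < 150 mg/kg, which is a limit of the assay and not a number, and it differs from the open-chain amides in more than one place.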